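This account rests on a few compounds, and the source may have more. Where it says the series, first, only, none or still open, it means among the compounds named here.

Three compounds have been measured so far in a functional assay on the whole organism (strain Wistar) for inhibition, with Rattus norvegicus as the target, read by paw edema, with stated times of 1 h and 3 h, at a dose of 200 mg/kg by the oral route; on this read-out lower numbers stand for less inhibition and higher numbers for more inhibition at the one dose given (going by the name of the read-out):

Compound 1 `CN(CC1CCC/C(=C\c2ccccc2)C1=O)c1ccccc1` gives 76.6%.
Compound 2 `Cc1ccc(/C=C2\CCCC(CN(C)c3cccc(C)c3)C2=O)cc1` gives 36.2%.
Compound 3 `CN(CC1CCC/C(=C\c2ccc(S(C)(=O)=O)cc2)C1=O)c1ccccc1` gives 51.1%.

Compound 3 stands second of the three: compound 1 sits above it, and that gap is beyond the scatter, while compound 2 sits below it, also beyond the scatter. The only single-place step among these is a number 25.5 percentage points lower from compound 1 to compound 3 (beyond the scatter), and it concerns a different group from the one now in question.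

Compound 4 `Cc1cccc(N(C)CC2CCC/C(=C\c3ccc(S(C)(=O)=O)cc3)C2=O)c1` differs from compound 3 by methyl in place of hydrogen on an aromatic carbon. Among the compounds with values here, no measured pair isolates this change. Compound 2 carries such a methyl on the same ring, and its value is lower than that of compound 1, but compound 2 also differs from compound 1 in a second place, so that comparison cannot be cleanly read. Within the data shown here, with no direct step to lean on, compound 4 is expected to lie near compound 3, with a slight downward lean given what compound 2 shows, so the step of a number 7.1 percentage points lower from compound 3 to compound 4 (within the scatter) is estimated to stay within the scatter, and compound 4 is estimated at 44%, within 24% to 64%.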

Compound 4, a percentage reported as inhibition, in the whole organism at one dose (the size of the read-out at that dose, not a potency): 36.2%
Compound 4: middle estimate off by 7.8 percentage points, on the high side; low and high end bracket the measured number.
By their numbers in this assay, from the lowest: compounds 2 and 4 (each within the scatter of the next); then compound 3; then compound 1.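

In this assay, the methyl meta to a large group now has a clean reading of its own: going from phenyl to 3-methylphenyl gives a number 14.9 percentage points lower from compound 3 to compound 4 (beyond the scatter), so this small addition alone changes the read-out in a compound carrying methylsulfonyl. With the 3-methylphenyl group in place, methylsulfonyl in place of methyl on an aromatic carbon gives no change at the digits printed from compound 2 to compound 4 (within the scatter), so this exchange does not separate the two compounds. No accompanying measurement gives a reason for either step.

From the compounds shown here alone, whether the same methyl would lower the number in compound 1, which lacks the methylsulfonyl group, remains open. Going by these compounds, it is also open how the read-out would respond to a chlorine atom, a methoxy group or an ethyl group in place of this methyl.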